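From Thiophen-2-yl to 2,4-Dichlorophenyl in Compound 1

The source may hold more compounds than are shown below. What is called first, only, known or untested is meant among the compounds shown, and "the series" means these compounds.

Going by the values given here, compound 1 `COC(=O)c1cc(-c2csc(N/N=C/c3cccs3)n2)ccc1OCc1ccccc1` is one of three compounds measured in a functional assay, read by spectrophotometry, with a stated time of 15 min, tested at 40 ug/mL (a higher number here means a stronger effect of the compound at the concentration tested, a lower number a weaker effect), where compound 1 gives 94.9%. Compound 2 `Clc1ccc(-c2csc(N/N=C/c3cccs3)n2)cc1` gives 96% and compound 3 `Fc1ccc(-c2csc(N/N=C/c3cccs3)n2)cc1` gives 93.3%, so compound 1 stands second of the three, yet all three values lie within the scatter of one another. Compound 4 `COC(=O)c1cc(-c2csc(N/N=C/c3ccc(Cl)cc3Cl)n2)ccc1OCc1ccccc1` differs from compound 1 by 2,4-dichlorophenyl in place of thiophen-2-yl on a carbon with a double bond to nitrogen. Among the compounds with values here, the only measured step, a number 2.7 percentage points lower from compound 2 to compound 3 (within the scatter), concerns a different place in the shared core and lay within the scatter. Within the data shown here, no step bears directly on the change at the carbon with a double bond to nitrogen, so for compound 4 no movement beyond the scatter is expected, with an estimated step of a number 1.9 percentage points lower from compound 1 to compound 4 (within the scatter). Compound 4 is therefore estimated at 93%, between 84% and 99%.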

Compound 4, a percentage reported as inhibition, at one concentration (the size of the read-out at that concentration, not a potency): 37.2%
The estimate for compound 4 lay 55.8 percentage points above the measured number, outside the stated range (below it).
By their numbers in this assay, from the lowest: compound 4; then compounds 3, 1 and 2 (each within the scatter of the next).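

All three earlier compounds carry thiophen-2-yl on the carbon with a double bond to nitrogen, so they said nothing about this position. Replacing that group with 2,4-dichlorophenyl gives a number 57.7 percentage points lower from compound 1 to compound 4 (beyond the scatter) in this assay, which shows that the read-out depends strongly on the group held here. Nothing measured on these compounds accounts for the drop.

The compounds shown leave open how an unsubstituted phenyl, a furan-2-yl or a pyridine ring on this carbon would read. They therefore also leave open whether the drop goes with losing thiophen-2-yl or with the two entering chlorines.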